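Dropping the Fluoro Substituent on the Way to Compound 4

The source may report more compounds than this note shows. Statements on the series, on what has been measured and on what is new or still open speak of the compounds shown alone.

Compound 1 `Cc1cc(C)cc(CNC(=O)CN(CCCCCC(=O)Nc2ccccc2N)C(=O)c2cc(C)cc(C)c2)c1` gives > 10000 nM in an assay on Sf9 cells for inhibition of protein deacetylase HDAC6 (Homo sapiens), read by fluorescence, with a stated time of 90 min; on this read-out higher numbers stand for weaker inhibition and lower numbers for stronger inhibition.
Compound 2 `Cc1cc(C)cc(C(=O)N(CC(=O)NCc2ccccc2)Cc2ccc(C(=O)Nc3cc(F)ccc3N)cc2)c1` gives > 10000 nM in this assay.
Compound 3 `CN(C)c1ccc(C(=O)N(CCCCCC(=O)Nc2cc(F)ccc2N)CC(=O)NCc2ccccc2)cc1` gives > 10000 nM in this assay.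

Each of these three values is a limit of the assay rather than a measured number. Compound 3 therefore stands where the other two stand, at the limit of > 10000 nM in this assay, at which 3 of the 3 values shown sit, and nothing separates it from them on the numbers shown. Among the compounds with values here, no two of the measured compounds differ in one place only, so no measured step exists to lean on.

Compound 4 `CN(C)c1ccc(C(=O)N(CCCCCC(=O)Nc2ccccc2N)CC(=O)NCc2ccccc2)cc1` differs from compound 3 by hydrogen in place of fluoro on an aromatic carbon. With every shown value sitting at the limit, the expected step is a step that the limit leaves unreadable from compound 3 to compound 4, which is taken to be none beyond the scatter in this assay. Compound 4 is thus expected to give about 15000 nM in this assay, most likely again as a limit. The estimated range for compound 4 runs from 4000 nM to 60000 nM.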

Compound 4, half-maximal inhibitory concentration: > 10000 nM
Compound 4 gave a limit, no number (the forecaster's own chance of this, stated with the estimate: 75%); the middle value lies beyond the limit too.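

In this assay compound 4 gives > 10000 nM, a limit of the assay. Compound 3 also sits at a limit, so no step from it to compound 4 can be read: the limit of > 10000 nM in this assay, at which 4 of the 4 values shown sit.

The compounds shown leave open whether hydrogen and fluoro differ at this place, and how strongly any of the four inhibits.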